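The compounds below may be only part of what the source reports. "The series", "measured", "known", "first", "only" and "open" are said of these compounds alone.

Measured so far in a functional assay on the whole organism (Tail, strain ICR) with Mus musculus as the target, in the tail flick test, with a stated time of 30 min, at a dose of 25 umol/kg by the oral route; a lower number here means a weaker effect, a higher number a stronger effect of the compound at the dose given:

compound 1 `O=C(O)CNC(=O)CN(c1nc(Cl)nc2[nH]cnc12)C1CC1` — 32.2%
compound 2 `CC(C)[C@H](NC(=O)CN(c1nc(Cl)nc2[nH]cnc12)C1CC1)C(=O)O` — 31.2%

Compound 2 and compound 1 share the same core and differ only by the isopropyl on the saturated chain carbon bound to the amide-type nitrogen and the carbonyl carbon. Within the data shown here, the step of a number 1 percentage points lower from compound 1 to compound 2 (within the scatter) lies within the scatter, so the two numbers cannot be told apart; compound 2 stands at the end of the series where no compound is clearly separated from it.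

Compound 3 `CSCC[C@H](NC(=O)CN(c1nc(Cl)nc2[nH]cnc12)C1CC1)C(=O)O` is not yet measured in this assay. It differs from compound 2 by 2-(methylsulfanyl)ethyl in place of isopropyl on a saturated chain carbon bound to an amide-type nitrogen and a carbonyl carbon.

Among the measured compounds shown here, the only measured step at this place is the one from compound 1 to compound 2, and it was within the scatter. The side chain at that carbon has so far not moved the read-out, so the present change is not expected to move it beyond the scatter either. Compound 3 is expected to give 31% in this assay, with a range of 20% to 42%. The expected step of a number 0.2 percentage points lower from compound 2 to compound 3 (within the scatter) thus stays within the scatter.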

Compound 3, a percentage reported as activity, at one dose (the size of the read-out at that dose, not a potency): 20.4%
For compound 3 the middle estimate is 10.6 percentage points above the measured one; the range from low to high includes it.
By their numbers in this assay, from the lowest: compound 3; then compounds 2 and 1 (each within the scatter of the next).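

In this assay, the side chain on the saturated chain carbon bound to an amide-type nitrogen and a carbonyl carbon turns out to matter for the read-out: 2-(methylsulfanyl)ethyl in place of isopropyl gives (a number 10.8 percentage points lower from compound 2 to compound 3 (beyond the scatter)), and 2-(methylsulfanyl)ethyl in place of hydrogen gives (a number 11.8 percentage points lower from compound 1 to compound 3 (beyond the scatter)). Isopropyl in place of hydrogen had stayed within the scatter (a number 1 percentage points lower from compound 1 to compound 2 (within the scatter)), so this position is not indifferent to every group, and the one step from hydrogen cannot stand for the others at this carbon. Nothing in hand speaks to why the 2-(methylsulfanyl)ethyl chain lowers the read-out.

The compounds shown leave open whether the lower number goes with the sulfur or with the longer chain, and a plain butyl chain at the same carbon would separate the two. Also open, on these data alone, is how the read-out responds at this carbon to a side chain ending in an amine or a carboxylic acid, or to a benzyl group.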